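Amide side-chain variation on a shared core: notes toward compound 4

The source may hold more compounds than are shown below. What is called first, only, known or untested is meant among the compounds shown, and "the series" means these compounds.

Measured so far in a functional assay on BXPC-3 cells (Homo sapiens) for antiproliferative activity, read by MTT assay, with a stated time of 24 h; a lower number here means a stronger inhibitor, a higher number a weaker inhibitor:
compound 1 `CCn1c(C(=O)NC(C)(C)CO)ccc1C(CC)(CC)c1ccc(OCS(=O)(=O)c2ccccc2)c(C)c1` gives 18300 nM
compound 2 `CCn1c(C(=O)N[C@@H](CO)C(C)C)ccc1C(CC)(CC)c1ccc(OCS(=O)(=O)c2ccccc2)c(C)c1` gives 13200 nM
compound 3 `CCn1c(C(=O)N[C@@H](CO)CCCO)ccc1C(CC)(CC)c1ccc(OCS(=O)(=O)c2ccccc2)c(C)c1` gives 16400 nM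

Compound 3 holds the second highest of the three values. Its nearest neighbour is compound 1, separated by a 1.1-fold lower number from compound 1 to compound 3 (0.05 log units; within the scatter); its furthest is compound 2, separated by a 1.2-fold higher number from compound 2 to compound 3 (0.09 log units; within the scatter). The remaining pair, compound 1 against compound 2, is covered by a 1.4-fold lower number from compound 1 to compound 2 (0.14 log units; within the scatter). All three steps alter only the substituent on the amide-type nitrogen, and none of them moves the number beyond the scatter.

Compound 4 `CCn1c(C(=O)N[C@H](CCC(=O)O)C(=O)O)ccc1C(CC)(CC)c1ccc(OCS(=O)(=O)c2ccccc2)c(C)c1` is not yet measured. It differs from compound 3 by a group of 9 heavy atoms (5 carbon, 4 oxygen; no ring) in place of a group of 7 heavy atoms (5 carbon, 2 oxygen; no ring), on an amide-type nitrogen. The measured steps bear on it only in the general sense that each earlier exchange at this same position, whether a branch was added or a hydroxyl-bearing chain lengthened, left this assay essentially unchanged. Going by the values given here, no measured pair places two carboxylic acids on that nitrogen substituent, so the range for compound 4 is kept wider than the scatter alone would demand. On this basis compound 4 is expected to give a value close to that of compound 3, a step of a 1.0-fold higher number from compound 3 to compound 4 (0.02 log units; within the scatter), with the estimate for compound 4 set at 17000 nM, between 6000 nM and 50000 nM.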

Compound 4, half-maximal inhibitory concentration: > 50000 nM
Compound 4: a limit, no number (the forecaster's own chance of this, stated with the estimate: 15%); middle value at least 2.9-fold (0.46 log units) away from the limit.
By their numbers in this assay, from the lowest: compounds 2, 3 and 1 (each within the scatter of the next). At a limit, above all of these: compound 4.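

In this assay compound 4 stands at a limit and not at a number: the limit of > 50000 nM in this assay, at which 1 of the 4 values shown sits. Among the changes shown on the amide-type nitrogen, this is the only one that reaches beyond the scatter, with an at least 3.0-fold higher number from compound 3 to compound 4 (0.48 log units; beyond the scatter) and an at least 3.7-fold higher number from compound 2 to compound 4 (0.57 log units; beyond the scatter) and an at least 2.7-fold higher number from compound 1 to compound 4 (0.43 log units; beyond the scatter) as its steps, each of them a minimum since one end is a limit. This position is therefore not indifferent to every substituent: compounds 1, 2 and 3 stay within the scatter of one another in this assay, whereas 1,3-dicarboxypropyl gives a weaker result than all three.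

The series leaves open how far the true value of compound 4 lies past its limit, and whether the step needs both carboxylic acids of 1,3-dicarboxypropyl or would follow from one alone. An amine or a methyl ester on the same chain would show whether the step belongs to the carboxylic acids themselves or to any such replacement of the hydroxyl-bearing chains.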